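A methoxyphenyl amide in place of a difluorophenyl amide

The source may hold more compounds than are shown below. What is called first, only, known or untested is meant among the compounds shown, and "the series" means these compounds.

Compound 1 `Cc1ccc(C(=O)Nc2cccc(-c3oc4cc(-c5ccc(F)cc5)ccc4c(=O)c3O)c2)cc1`: in a functional assay on HeLa cells (Homo sapiens) for antiproliferative activity, read by CCK-8 assay, with a stated time of 72 h (a lower number here means a stronger inhibitor, a higher number a weaker inhibitor), compound 1 gives 6190 nM.
Compound 2 `O=C(Nc1cccc(-c2oc3cc(-c4ccc(F)cc4)ccc3c(=O)c2O)c1)c1ccc(F)cc1F`: in this assay compound 2 gives 10700 nM.

Compound 2 stands at the upper end of these two numbers, yet its distance to compound 1 is small, as the step from one to the other shows: a 1.7-fold higher number from compound 1 to compound 2 (0.24 log units; within the scatter). Both compounds share the same core and differ only in the aryl group attached to the carbonyl carbon of the amide.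

Compound 3 `COc1ccccc1C(=O)Nc1cccc(-c2oc3cc(-c4ccc(F)cc4)ccc3c(=O)c2O)c1` changes that same position once more: 2-methoxyphenyl in place of 2,4-difluorophenyl on a carbonyl carbon. Among the measured compounds shown here, the only measured step that bears on such a change is the one from compound 1 to compound 2, and it stayed within the scatter. Nothing measured here shows that swapping this aryl group shifts the number beyond the scatter, so no clear move in either direction is expected in this assay. The step is expected to be a 1.3-fold lower number from compound 2 to compound 3 (0.10 log units; within the scatter). Compound 3 is therefore estimated at 8500 nM, with a range from 3000 nM to 25000 nM.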

Compound 3, half-maximal inhibitory concentration: 14100 nM
Compound 3: the middle estimate sits 1.7-fold (0.22 log units) below what was measured; low and high end bracket the measured number.
By their numbers in this assay, from the lowest: compounds 1, 2 and 3 (each within the scatter of the next, the first and the last beyond it).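

In this assay, 2-methoxyphenyl in place of 2,4-difluorophenyl on the carbonyl carbon gives a 1.3-fold higher number from compound 2 to compound 3 (0.12 log units; within the scatter), so this second swap of the aryl group also leaves the number within the scatter. Among the compounds shown here, the new information comes from setting the same group against 4-methylphenyl, which gives a 2.3-fold higher number from compound 1 to compound 3 (0.36 log units; beyond the scatter), the first pair at this position to pass the scatter, though only modestly. No measurement here accounts for that gap.

Going by these compounds, all three compounds carry a substituted phenyl ring on this carbonyl carbon, so the effect of an amine, a carboxylic acid or a longer chain in its place remains open. The core also stays the same throughout, which leaves open how changes elsewhere on it would act.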